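Pyrazole attachment point and maximal response at alpha-1D

The source may report more compounds than this note shows. Statements on the series, on what has been measured and on what is new or still open speak of the compounds shown alone.

Measured compounds:
compound 1 `Cn1cc(-c2ccccc2NCC2=NCCN2)cn1`, 0%
compound 2 `CC(C)n1nccc1-c1ccccc1NCC1=NCCN1`, 0%
compound 3 `Cn1ccc(-c2ccccc2NCC2=NCCN2)n1`, 29%

In a functional assay with Alpha-1D adrenergic receptor (Homo sapiens) as the target, read by calcium flux (on this read-out lower numbers stand for smaller maximal responses and higher numbers for larger maximal responses), compound 3 holds the highest number of the three. For the measured compounds named here, compound 1 and compound 2 both sit at the bottom, and the only single-point step available, a number 29 percentage points higher from compound 1 to compound 3 (beyond the scatter), shows that moving the pyrazole attachment from 1-methyl-1H-pyrazol-4-yl to 1-methyl-1H-pyrazol-3-yl raises the maximal response beyond the scatter.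

Compound 4 `Cn1nccc1-c1ccccc1NCC1=NCCN1` is not yet measured. It differs from compound 3 in one place: 1-methyl-1H-pyrazol-5-yl in place of 1-methyl-1H-pyrazol-3-yl on an aromatic carbon.

Going by the values given here, no measured step covers this exact change. The step of a number 29 percentage points higher from compound 1 to compound 3 (beyond the scatter) only tells that the attachment point of the pyrazole matters and that a change there can shift the read-out by a modest amount. Compound 2, which carries a pyrazol-5-yl attachment with a larger alkyl group on the ring nitrogen, gives 0%, the same number as compound 1. Taken together, the two pyrazole attachments measured so far other than that of compound 3 give no response at all, so a step down from compound 3 is expected, roughly a number 24 percentage points lower from compound 3 to compound 4 (beyond the scatter).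

Compound 4 is therefore estimated at 5% in this assay, with a likely range from 0% to 25%.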

Compound 4, largest response reached (reported as maximal response), in percent of the reference or control that the assay uses: 0%
The estimate for compound 4 lay 5 percentage points above the measured number; low and high end bracket the measured number.
By their numbers in this assay, from the lowest: compounds 1, 2 and 4 (each within the scatter of the next); then compound 3.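

In this assay, the 1-methyl-1H-pyrazole now appears with all three attachments on the aromatic carbon, and replacing 1-methyl-1H-pyrazol-3-yl with 1-methyl-1H-pyrazol-5-yl gives a number 29 percentage points lower from compound 3 to compound 4 (beyond the scatter) while replacing 1-methyl-1H-pyrazol-4-yl with 1-methyl-1H-pyrazol-5-yl gives no change at the digits printed from compound 1 to compound 4 (within the scatter) in this methyl set. Compound 3 is thus the only one of the three attachments with a maximal response separated from the others, so the earlier contrast is not special to the 4-yl attachment. Methyl in place of isopropyl on the aromatic nitrogen gives no change at the digits printed from compound 2 to compound 4 (within the scatter) at the 5-yl attachment, so the reading of compound 2 no longer depends on its alkyl group alone, and no evidence at hand explains the effect of the attachment point.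

Still open, as far as these compounds go, is whether the response of compound 3 persists with ethyl, isopropyl or a plain hydrogen on the ring nitrogen at the 3-yl attachment. Equally open, from the compounds shown here alone, is whether another five-membered ring, such as an imidazole or a thiazole, can take the place of the pyrazole at this position and give any response in this assay at all.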